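Bromo for Hydrogen on the Benzamide Ring

The compounds below may be only part of what the source reports. "The series", "measured", "known", "first", "only" and "open" are said of these compounds alone.

Measured compounds:
compound 1 `CCOC(=O)Cc1n[nH]c(N)n1` — 33.6%
compound 2 `CCOC(=O)Cc1nc(N)n(C(=O)c2ccc(OC)cc2)n1` — 41.5%
compound 3 `CCOC(=O)Cc1n[nH]c(NC(=O)c2ccccc2)n1` — 36.2%

The three compounds share one core and were tested in a functional assay on the whole organism (strain albino) for inhibition, with Rattus norvegicus as the target, read by paw edema, with stated times of 30 min and 2 h, at a dose of 5 mg/kg by the oral route; on this read-out higher numbers stand for more inhibition at the one dose given (going by the name of the read-out) and lower numbers for less inhibition. In this assay compound 1 gives 33.6%, compound 2 gives 41.5% and compound 3 gives 36.2%. On these numbers compound 3 sits between the other two, with compound 1 the nearer neighbour, yet its gap to compound 1 and its gap to compound 2 both stay within the usual scatter of repeated measurements, so the three values cannot be told apart with confidence.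

Compound 4 `CCOC(=O)Cc1n[nH]c(NC(=O)c2ccc(Br)cc2)n1` has not yet been measured. It differs from compound 3 in one place: bromo in place of hydrogen on an aromatic carbon. No hydrogen-bond donor or acceptor is added, and no ring; seen one bond further out, the change reads phenyl to 4-bromophenyl, para to a large group.

Going by the values given here, nothing among the measured compounds shows how a bromo on this ring moves the read-out, since all three known values lie within the scatter of one another. The step from compound 3 to compound 4 is therefore expected to be small, in no fixed direction, and not beyond the scatter: a number 1.8 percentage points higher from compound 3 to compound 4 (within the scatter). The estimated value for compound 4 is 38%, expected to fall between 25% and 52%.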

Compound 4, a percentage reported as inhibition, in the whole organism at one dose (the size of the read-out at that dose, not a potency): 40.4%
Compound 4: the middle estimate sits 2.4 percentage points below what was measured; the range from low to high includes it.
By their numbers in this assay, from the lowest: compounds 1, 3, 4 and 2 (each within the scatter of the next).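

In this assay, going by these compounds alone, bromo in place of hydrogen on an aromatic carbon, para to a large group, gives a number 4.2 percentage points higher from compound 3 to compound 4 (within the scatter) and so provides the first direct reading of this position. The phenyl to 4-bromophenyl change therefore adds one heavy atom, with no ring and no hydrogen-bond donor or acceptor, and does not shift inhibition at this one dose by more than repeated measurements would scatter; the position accepts a bromo without a loss that can be told apart, and equally without a gain that can be claimed. No measurement shown here bears on why the step has this size.

On these data alone, a single small atom swap at one place cannot show whether this position responds at all, so it stays open whether an amine, a carboxylic acid or a longer chain such as n-butyl in place of the bromo would carry the read-out beyond the scatter. As far as these compounds go, with every reading taken at one oral dose, the shape of the dose response for compound 3 and compound 4 also remains open.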